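The source may report more compounds than this note shows. Statements on the series, on what has been measured and on what is new or still open speak of the compounds shown alone.

Of the compounds shown here, three that share the same core have been measured in a functional assay on PANC-1 cells (Homo sapiens) for inhibition, read by MTT assay, with a stated time of 24 h, tested at 10 uM; on this read-out higher numbers stand for more inhibition at the one concentration tested (going by the name of the read-out) and lower numbers for less inhibition. Compound 1 `COc1ccc(C(=O)NCCCOc2cc(=O)n(CCCO)c3c2CC(CC=C(C)C)C(C)(C)C3)cc1` gives 2.5%. Compound 2 `CC(C)=CCC/C(C)=C/CC1Cc2c(OCCCNS(=O)(=O)c3ccc(Cl)cc3)cc(=O)n(CCCO)c2CC1(C)C` gives 16.1%. Compound 3 `CC(C)=CCC/C(C)=C/CC1Cc2c(OCCCNS(=O)(=O)c3ccc([N+](=O)[O-])cc3)cc(=O)n(CCCO)c2CC1(C)C` gives 0%. Within the data shown here, the one step between neighbours, a number 16.1 percentage points lower from compound 2 to compound 3 (beyond the scatter), is the only change for which a direct comparison exists. Compound 3 therefore sits at the bottom of the three numbers, with compound 1 within the scatter of it and compound 2 beyond it.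

Compound 4 `COc1ccc(C(=O)NCCCOc2cc(=O)n(CCCO)c3c2CC(C/C=C(\C)CCC=C(C)C)C(C)(C)C3)cc1` is obtained from compound 3 by the change ((4-methoxyphenyl)carbonyl in place of (4-nitrophenyl)sulfonyl on an amine nitrogen). Among the measured compounds shown here, no measured step covers this exact swap. Compound 1 carries the same (4-methoxyphenyl)carbonyl group and differs from compound 4 only in its chain, and compound 1 and compound 3 lie within the scatter of each other. The step from chloro to nitro gave only a modest fall, so no large shift is expected here either. Compound 4 is expected to stay near the low end, with the step of a number 4 percentage points higher from compound 3 to compound 4 (within the scatter) within the scatter. The estimate for compound 4 is 4%, in the range 0% to 16%.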

Compound 4, a percentage reported as inhibition, at one concentration (the size of the read-out at that concentration, not a potency): 14.1%
Estimate against measurement, compound 4: 10.1 percentage points below; the measured number falls inside the stated range.
By their numbers in this assay, from the lowest: compounds 3 and 1 (each within the scatter of the next); then compounds 4 and 2 (each within the scatter of the next).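

In this assay, the group on the amine nitrogen now shows a clear difference: (4-methoxyphenyl)carbonyl in place of (4-nitrophenyl)sulfonyl gives a number 14.1 percentage points higher from compound 3 to compound 4 (beyond the scatter) and (4-methoxyphenyl)carbonyl in place of (4-chlorophenyl)sulfonyl gives a number 2 percentage points lower from compound 2 to compound 4 (within the scatter) so a sulfonyl link and a carbonyl link can read alike on this chain. The chain also counts, since 3-methylbut-2-en-1-yl in place of hydrogen on a saturated chain carbon bound to a double-bonded chain carbon gives a number 11.6 percentage points higher from compound 1 to compound 4 (beyond the scatter) with the (4-methoxyphenyl)carbonyl group held constant. No supporting measurement is available to explain either finding.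

Still open, as far as these compounds go, is whether the link or the ring substituent decides the result, which a (4-methoxyphenyl)sulfonyl group on the same nitrogen could separate. A longer chain than that of compound 4 also remains to be placed on this scale.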